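Working notes on a cytotoxicity series and its chloro analogue

The compounds below may be only part of what the source reports. "The series", "measured", "known", "first", "only" and "open" are said of these compounds alone.

Measured compounds:
compound 1 `Cc1nnc(SCc2cc(=O)c3ccccc3o2)o1` — a limit only, > 25000 nM
compound 2 `Cc1cc(O)cc2oc(=O)cc(CSc3nc4ccccc4[nH]3)c12` — a limit only, > 25000 nM
compound 3 `Nc1nnc(SCc2cc(=O)c3ccccc3o2)s1` — a limit only, > 25000 nM

In a functional assay on SW480 cells (Homo sapiens) for cytotoxicity, read by MTT assay, with a stated time of 72 h (on this read-out higher numbers stand for weaker inhibition and lower numbers for stronger inhibition), compound 1 gives no number, only a limit, > 25000 nM. Compound 3 likewise stands at a limit in this assay, > 25000 nM. Compound 2 too is reported as a limit in this assay, > 25000 nM. The one step between compounds differing in a single place, a step that the two limits leave unreadable from compound 1 to compound 3, therefore cannot be read, because the limit of > 25000 nM in this assay, at which 3 of the 3 values shown sit, is where all the shown values sit.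

Compound 4 `Cc1nnc(SCc2cc(=O)c3cc(Cl)ccc3o2)o1` differs from compound 1 by chloro in place of hydrogen on an aromatic carbon. Among the measured compounds shown here, no measured step bears on this change, and no measured step has a readable size at all. The expectation for compound 4 is therefore simply that it stays where compound 1 stands, with the step that the limit leaves unreadable from compound 1 to compound 4 expected to be none beyond the scatter. Compound 4 is estimated at 35000 nM in this assay, between 12000 nM and 100000 nM, most probably reported again as a limit.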

Compound 4, half-maximal inhibitory concentration: > 25000 nM
Compound 4: a limit, no number; the forecaster's own chance of this, stated with the estimate: 80%; the middle value is on the limit's open side.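

No step can be read between compound 1 and compound 4, whose chloro in place of hydrogen leaves both at the same limit: the limit of > 25000 nM in this assay, at which 4 of the 4 values shown sit.

The compounds shown leave open whether any change to the shared core gives a numerical value in this assay and how large such a step would be.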